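Removing the bromo group from compound 3

The compounds below may be only part of what the source reports. "The series", "measured", "known", "first", "only" and "open" are said of these compounds alone.

Values in a functional assay on A-431 cells (Homo sapiens) for inhibition, read by MTT assay, with a stated time of 72 h; a higher number here means a weaker inhibitor, a lower number a stronger inhibitor:
- compound 1 `COc1ccc(-c2nnc(SCCCN3CCN(c4nc5ccccc5s4)CC3)o2)cc1`: 56200 nM
- compound 2 `Fc1ccc(-c2nnc(SCCCN3CCN(c4nc5ccccc5s4)CC3)o2)cc1`: 67000 nM
- compound 3 `Brc1ccc(-c2nnc(SCCCN3CCN(c4nc5ccccc5s4)CC3)o2)cc1`: 51600 nM

In this assay compound 3 gives 51600 nM, and this value cannot be separated from those of the other two compounds. Methoxy gives way to bromo in a 1.1-fold lower number from compound 1 to compound 3 (0.04 log units; within the scatter), and fluoro gives way to bromo in a 1.3-fold lower number from compound 2 to compound 3 (0.11 log units; within the scatter). Both steps lie within the scatter.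

The next compound is compound 4 `c1ccc(-c2nnc(SCCCN3CCN(c4nc5ccccc5s4)CC3)o2)cc1`, not yet measured. It follows from compound 3 by hydrogen in place of bromo on an aromatic carbon, that is, 4-bromophenyl to phenyl: hydrogen in place of bromo on an aromatic carbon.

Going by the values given here, three measured steps bear on this change. Besides the two above, fluoro in place of methoxy gives a 1.2-fold higher number from compound 1 to compound 2 (0.08 log units; within the scatter), also within the scatter. Among the compounds with values here, all three exchange one aromatic substituent for another, and none of them introduces hydrogen, so the change to compound 4 has no direct precedent. Since methoxy, fluoro and bromo give values within the scatter of one another, no step beyond the scatter is expected in this assay, and no direction is firmly expected. The estimated step is a 1.1-fold higher number from compound 3 to compound 4 (0.05 log units; within the scatter). Compound 4 is expected at about 58000 nM, with an estimated range of 35000 nM to 95000 nM.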

Compound 4, half-maximal inhibitory concentration: 93400 nM
Compound 4: middle estimate off by 1.6-fold (0.21 log units), on the low side; low and high end bracket the measured number.
By their numbers in this assay, from the lowest: compounds 3, 1, 2 and 4 (each within the scatter of the next).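

Hydrogen on this aromatic carbon, para to a large group, now has a reading in this assay: the series gives a 1.8-fold higher number from compound 3 to compound 4 (0.26 log units; within the scatter) and a 1.4-fold higher number from compound 2 to compound 4 (0.14 log units; within the scatter) and also a 1.7-fold higher number from compound 1 to compound 4 (0.22 log units; within the scatter) for the three exchanges that end in the plain phenyl. All three steps lie within the scatter, so the change from 4-bromophenyl to phenyl cannot be told apart from no change at all, and the same holds for the exchanges from the fluoro and methoxy groups. Compound 4 thus adds the case with no substituent at this place to the three substituted compounds, and the four together show no measurable preference among hydrogen, fluoro, bromo and methoxy here.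

Still open, going by these compounds, is whether any group at this place can move the number beyond the scatter, for instance an amine or a carboxylic acid on the same aromatic carbon, and whether a change elsewhere, such as a longer chain in the linker, would do so. Nothing at hand explains why these four values lie together, or whether the shared core alone sets them.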